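This account rests on a few compounds, and the source may have more. Where it says the series, first, only, none or still open, it means among the compounds named here.

Two compounds of a shared core, differing at both ends of the molecule, have been tested in a functional assay on OVCAR-3 cells (Homo sapiens) for inhibition; on this read-out higher numbers stand for weaker inhibition of growth and lower numbers for stronger inhibition of growth. Compound 1 `O=C(/C=C/c1cccc(O)c1)c1cccc(-n2cc(-c3ccc(Cl)cc3)[nH]c2=O)c1` gives 1560 nM. Compound 2 `COc1ccc(-c2cn(-c3cccc(C(=O)/C=C/c4ccc(O)c(OC)c4)c3)c(=O)[nH]2)cc1` gives 2700 nM in this assay, and the gap between compound 2 and compound 1 lies within the scatter of repeated measurements, so the two numbers cannot be told apart with confidence.

Compound 3 `COc1cc(/C=C/C(=O)c2cccc(-n3cc(-c4ccc(Cl)cc4)[nH]c3=O)c2)ccc1O` is obtained from compound 2 by a single exchange: chloro in place of methoxy on an aromatic carbon. Within the data shown here, no measured pair in this set isolates that exchange on its own, so there is no direct precedent for its effect. Since the two measured compounds, which carry chloro and methoxy at this position alongside other differences, sit within the scatter of each other, the step is expected to be small and no larger than the scatter, in either direction, as a 1.4-fold lower number from compound 2 to compound 3 (0.13 log units; within the scatter) shows. Compound 3 is therefore estimated at 2000 nM, with a likely range from 800 nM to 5000 nM.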

Compound 3, concentration for 50% growth inhibition: 1560 nM
Compound 3: the middle estimate sits 1.3-fold (0.11 log units) above what was measured; the measured number falls inside the stated range.
By their numbers in this assay, from the lowest: compounds 1, 3 and 2 (each within the scatter of the next).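

Among these compounds, compound 3 isolates this position for the first time: in this assay, chloro in place of methoxy gives a 1.7-fold lower number from compound 2 to compound 3 (0.24 log units; within the scatter) with the rest of the molecule unchanged, so this exchange has no effect that can be told from the scatter. The other end of the molecule can now be read alone too, and 4-hydroxy-3-methoxyphenyl in place of 3-hydroxyphenyl gives no change at the digits printed from compound 1 to compound 3 (within the scatter) and likewise leaves no readable effect. Nothing available explains why either exchange leaves the number so little changed.

The compounds shown leave open whether a different group at this position, such as an amine or a carboxylic acid, would move the number beyond the scatter. They also leave open whether chloro and methoxy would remain indistinguishable with other groups at the far end of the molecule.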